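Adding chloro to compound 2

The source may hold more compounds than are shown below. What is called first, only, known or untested is meant among the compounds shown, and "the series" means these compounds.

- compound 1 `COc1ccc(Cc2cn3cc(Br)ccc3nc2=O)cc1`: 928000 nM
- compound 2 `O=c1nc2ccccn2cc1Cc1ccc(F)cc1C(F)(F)F`: 88000 nM

In a functional assay on HeLa cells (Homo sapiens) for cytotoxicity, read by MTT assay, with a stated time of 24 h (on this read-out higher numbers stand for weaker inhibition and lower numbers for stronger inhibition), compound 2 gives 88000 nM, the lower of the two numbers, and compound 1 gives 928000 nM. The gap between these two numbers lies beyond the scatter. Compound 3 `O=c1nc2ccc(Cl)cn2cc1Cc1ccc(F)cc1C(F)(F)F` departs from compound 2 in one place: chloro in place of hydrogen on an aromatic carbon. Going by the values given here, no measured pair shows this change alone, so no step beyond the scatter is expected in this assay. The expected result is a 1.1-fold higher number from compound 2 to compound 3 (0.03 log units; within the scatter). The estimate for compound 3 is 95000 nM, with an expected range of 30000 nM to 280000 nM.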

Compound 3, half-maximal inhibitory concentration: > 1000000 nM
Compound 3: a limit, no number; the forecaster's own chance of this, stated with the estimate: 5%; middle value at least 10-fold (1.02 log units) from the limit.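

In this assay, going by these compounds alone, chloro in place of hydrogen on an aromatic carbon, two atoms from the ring nitrogen, gives an at least 11-fold higher number from compound 2 to compound 3 (1.05 log units; beyond the scatter), so this single-atom change at this position carries a large penalty that the earlier compounds could not reveal. Compound 3 gives > 1000000 nM, which is a limit of the assay and not a number. The full size of the step therefore stays unknown, and the reading sits at the edge of the assay: the limit of > 1000000 nM in this assay, at which 1 of the 3 values shown sits.

The compounds shown leave open whether an amine or a nitrile at this position would shift the number as chloro does. They also leave open whether chloro on another carbon of this ring would do the same.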